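Tert-butyl in place of acetyl: working notes

The source may report more compounds than this note shows. Statements on the series, on what has been measured and on what is new or still open speak of the compounds shown alone.

- compound 1 `COc1cc(-c2ccnc3cc(-c4ccc(Cl)cc4)nn23)cc(OC)c1OC` gives 2320 nM
- compound 2 `COc1cc(-c2ccnc3cc(-c4ccc(C)cc4)nn23)cc(OC)c1OC` gives 47 nM
- compound 3 `COc1cc(-c2ccnc3cc(-c4ccc(C(C)=O)cc4)nn23)cc(OC)c1OC` gives 5230 nM

All three values come from a functional assay on MCF7 cells (Homo sapiens) for inhibition, read by CCK-8 assay, with a stated time of 48 h (a lower number here means a stronger inhibitor, a higher number a weaker inhibitor), and share one core. Compound 3 has the highest number of the three, 5230 nM on this read-out, which makes it the weakest inhibitor measured so far. Compound 1 lies nearest to it and compound 2 furthest away.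

The next change leads to compound 4 `COc1cc(-c2ccnc3cc(-c4ccc(C(C)(C)C)cc4)nn23)cc(OC)c1OC` with tert-butyl in place of acetyl on an aromatic carbon, para to a large group: tert-butyl in place of acetyl on an aromatic carbon is the full difference.

Among the compounds with values here, the closest precedent is a 110-fold higher number from compound 2 to compound 3 (2.05 log units; beyond the scatter) for acetyl in place of methyl, a large step that, read in reverse, favours an alkyl group over acetyl. Also relevant are a 49-fold lower number from compound 1 to compound 2 (1.69 log units; beyond the scatter) for methyl in place of chloro and the modest 2.3-fold higher number from compound 1 to compound 3 (0.35 log units; beyond the scatter) for acetyl in place of chloro. Methyl is the only alkyl group measured, and no data cover tert-butyl itself, so only part of the methyl gain is expected to carry over. The expected change in this assay is a 10-fold lower number from compound 3 to compound 4 (1.02 log units; beyond the scatter) and thus a move towards stronger inhibition. For compound 4 the estimated value is 500 nM with an expected range from 60 nM to 4000 nM on this read-out.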

Compound 4, half-maximal inhibitory concentration: > 10000 nM
Compound 4 ended at the assay's limit; the forecaster's own chance of this, stated with the estimate: 3%; at least 20-fold (1.30 log units) between middle value and limit.
By their numbers in this assay, from the lowest: compound 2; then compound 1; then compound 3. At a limit, above all of these: compound 4.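

In this assay compound 4 stands at a limit and not at a number: the limit of > 10000 nM in this assay, at which 1 of the 4 values shown sits.

Methyl and tert-butyl are both alkyl groups on the same aromatic carbon, yet they lie far apart, with an at least 210-fold higher number from compound 2 to compound 4 (2.32 log units; beyond the scatter), so the low number of compound 2 cannot be read as a gain shared by alkyl groups at this place in the series. Going by these compounds, the remaining comparisons are less sharp: an at least 4.3-fold higher number from compound 1 to compound 4 (0.63 log units; beyond the scatter) separates tert-butyl from chloro, while an at least 1.9-fold higher number from compound 3 to compound 4 (0.28 log units; that floor lies within the scatter) leaves the order of tert-butyl and acetyl unsettled, and the true distance of compound 4 from any of the others stays unknown.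

Open, on these data alone, is where between methyl and tert-butyl the numbers turn, a question that ethyl or isopropyl on the same aromatic carbon would address directly. Also open, as far as these compounds go, is whether methyl stands alone among the groups at this place or is matched by a quite different one, such as methoxy, an amine or a carboxylic acid.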